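A few compounds are considered here, and "the series" means these few. Any claim that something is new, unique, unknown or untested is made for them only; others in the source may bear on it.

Working notes on the sulfonyl imidazolidinone series.

Three compounds carry measurements in a functional assay on NCI-H460 cells (Homo sapiens) for cytotoxicity, read by MTT assay; on this read-out lower numbers stand for stronger inhibition and higher numbers for weaker inhibition. Compound 1 `CCOC(=O)Nc1ccc(S(=O)(=O)N2C[C@H](c3ccccc3)NC2=O)cc1C` gives 70 nM in this assay. Compound 2 `Cc1cc(S(=O)(=O)N2C(=O)N[C@@H](c3ccccc3)C2C)ccc1NC(=O)c1ccc([N+](=O)[O-])cc1` reaches only the limit of the assay, > 10000 nM, which is a limit and not a number. Compound 3 `CCOC(=O)Nc1ccc(S(=O)(=O)N2C(=O)N[C@@H](c3ccccc3)C2C)cc1Cl` gives 6000 nM in this assay, the highest of the two numbers recorded; the nearest number is that of compound 1, which sits far lower, well beyond the usual scatter. Among the compounds with values here, compound 3 shares the ethyl carbamate of compound 1 but differs from it in two places, so no single step between the two is drawn here.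

Compound 4 `CCOC(=O)Nc1ccc(S(=O)(=O)N2C(=O)N[C@@H](c3ccccc3)C2C)cc1C` has not yet been measured. From compound 3 to compound 4 the change is methyl in place of chloro on an aromatic carbon, ortho to the (ethoxycarbonyl)amino group. Compound 1, which carries the same methyl next to the same carbamate, is the low number of the set at 70 nM, while compound 3 with chloro sits at 6000 nM; on that basis a step toward a lower number is expected for compound 4, of size a 4.0-fold lower number from compound 3 to compound 4 (0.60 log units; beyond the scatter). Compound 4 is therefore estimated at 1500 nM, with a range from 300 nM to 8000 nM.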

Compound 4, half-maximal inhibitory concentration: 5000 nM
Compound 4: middle estimate off by 3.3-fold (0.52 log units), on the low side, and the stated range covers the measured number.
By their numbers in this assay, from the lowest: compound 1; then compounds 4 and 3 (each within the scatter of the next). At a limit, above all of these: compound 2.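

In this assay, methyl in place of chloro on an aromatic carbon, ortho to the (ethoxycarbonyl)amino group, is a small change on this core: a 1.2-fold lower number from compound 3 to compound 4 (0.08 log units; within the scatter). The large gap instead appears at the saturated ring carbon, where methyl in place of hydrogen gives a 71-fold higher number from compound 1 to compound 4 (1.85 log units; beyond the scatter), so the low number of compound 1 goes with the hydrogen at that carbon and not with the methyl on the aromatic carbon, which compound 1 and compound 4 share. For ethoxy in place of 4-nitrophenyl on a carbonyl carbon, an at least 2.0-fold lower number from compound 2 to compound 4 (0.30 log units; that floor lies within the scatter) gives only a floor, since compound 2 stands at a limit and not at a number: the limit of > 10000 nM in this assay, at which 1 of the 4 values shown sits.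

On these data alone, it remains open whether an ethyl or a hydroxymethyl on the saturated ring carbon would behave as the methyl of compound 4 does, and whether hydrogen there would give a similarly low number with chloro on the aromatic carbon. As far as these compounds go, it also remains open how a methoxy or an amine on that aromatic carbon would compare with chloro and methyl, and how a longer chain in place of ethoxy on the carbamate would read.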